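A few compounds are considered here, and "the series" means these few. Any claim that something is new, unique, unknown or untested is made for them only; others in the source may bear on it.

In a functional assay on MCF7 cells (Homo sapiens) for antiproliferative activity, read by MTT assay, with a stated time of 72 h (on this read-out higher numbers stand for weaker inhibition and lower numbers for stronger inhibition), three compounds built on a shared core have been measured. Compound 1 `CCN(CC)CCNc1cc(C)c2cc(NC(=O)c3ccc(Cl)c(Cl)c3)ccc2n1` gives 1420 nM, compound 3 `Cc1cc(N2CCN(C)CC2)nc2ccc(NC(=O)c3ccc(Cl)c(Cl)c3)cc12` gives 3000 nM, and compound 2 `CCN1CCN(c2cc(C)c3cc(NC(=O)c4ccc(OC)cc4)ccc3n2)CC1` gives 7690 nM, the highest of the three numbers. Within the data shown here, the only recorded single-point step, a 2.1-fold higher number from compound 1 to compound 3 (0.32 log units; beyond the scatter), concerns the group at the other end of the core, not the amide side. Compound 4 `CCN1CCN(c2cc(C)c3cc(NC(=O)c4ccc(C)cc4)ccc3n2)CC1` differs from compound 2 by methyl in place of methoxy on an aromatic carbon. No measured step touches that part of the molecule, so nothing among these compounds points to a move in this assay beyond the scatter in either direction. Compound 4 is therefore expected to give about 7500 nM, within a range from 3000 nM to 18000 nM, an expected step of a 1.0-fold lower number from compound 2 to compound 4 (0.01 log units; within the scatter).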

Compound 4, half-maximal inhibitory concentration: 6740 nM
The estimate for compound 4 lay 1.1-fold (0.05 log units) above the measured number; measured number inside the range.
By their numbers in this assay, from the lowest: compound 1; then compound 3; then compounds 4 and 2 (each within the scatter of the next).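

In this assay, among these compounds, the change from 4-methoxyphenyl to 4-methylphenyl gives a 1.1-fold lower number from compound 2 to compound 4 (0.06 log units; within the scatter), the first measured step on the amide side of the shared core. At this place, para to a large group, methyl and methoxy therefore cannot be told apart in this assay. Nothing measured here bears on why the two read alike. On these data alone, whether an amine, a carboxylic acid or a longer chain at this place would also leave the number within the scatter remains open. So does whether methyl and methoxy would read alike with the side chain of compound 1 at the other end of the core.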